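The source may report more compounds than this note shows. Statements on the series, on what has been measured and on what is new or still open speak of the compounds shown alone.

Compound 1 `NC(=O)c1c(NC(=O)c2ccccc2Cl)sc2c1CCN(C(=S)Nc1ccccc1C(F)(F)F)C2` is the reference point of this small set. In a functional assay on HeLa cells (Homo sapiens) for antiproliferative activity, with a stated time of 24 h (a higher number here means a weaker inhibitor, a lower number a stronger inhibitor), compound 1 gives 26700 nM.

Compound 2 `COc1ccccc1NC(=S)N1CCc2c(sc(NC(=O)c3ccccc3Cl)c2C(N)=O)C1` differs from compound 1 in one place: methoxy in place of trifluoromethyl on an aromatic carbon. In this assay compound 2 gives > 50000 nM, which is a limit of the assay and not a number; it sits at the limit of > 50000 nM in this assay, at which 1 of the 3 values shown sits. The step is an at least 1.8-fold higher number from compound 1 to compound 2 (0.27 log units; that floor lies within the scatter).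

Compound 3 `NC(=O)c1c(NC(=O)c2ccccc2I)sc2c1CCN(C(=S)Nc1ccccc1C(F)(F)F)C2` differs from compound 1 in a different place, on the other aryl ring, and in this assay compound 3 gives 49200 nM. The step is a 1.8-fold higher number from compound 1 to compound 3 (0.27 log units; within the scatter), so the two values are not told apart here.

Compound 4 `COc1ccccc1NC(=S)N1CCc2c(sc(NC(=O)c3ccccc3I)c2C(N)=O)C1` has not yet been measured in this assay. It differs from compound 3 by methoxy in place of trifluoromethyl on an aromatic carbon. The two cores on which this change is made, that of compound 1 and that of compound 3, differ by iodo in place of chloro on an aromatic carbon. The place of the change is described in the same words for both pairs, so the change is the same change, made on a core that already carries iodo in place of chloro.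

From compound 3 to compound 4 the expected step is a 1.8-fold higher number from compound 3 to compound 4 (0.26 log units; within the scatter), resting on the step from compound 1 to compound 2 in the same assay, an at least 1.8-fold higher number from compound 1 to compound 2 (0.27 log units; that floor lies within the scatter), applied to the starting value of compound 3, 49200 nM. Since compound 3 already stands close to the limit at which compound 2 sits, the most likely outcome for compound 4 is that the assay again reports only a limit. The estimate for compound 4 is 90000 nM, expected to lie between 40000 nM and 250000 nM.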

Compound 4, half-maximal inhibitory concentration: > 50000 nM
Compound 4: only a limit was reported; the forecaster's own chance of this, stated with the estimate: 80%; the middle value lies beyond the limit too.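

Methoxy in place of trifluoromethyl on the iodo-bearing core gives an at least 1.0-fold higher number from compound 3 to compound 4 (0.00 log units; that floor lies within the scatter) in this assay, and that floor is all that can be read, since the entry for compound 4 is a limit of the assay and not a number. Set beside the same change on the chloro-bearing core, the result gives no measure of whether the change carries over with the same size: the same change on two cores in this assay, an at least 1.8-fold higher number (0.27 log units; that floor lies within the scatter) from compound 1 to compound 2 and an at least 1.0-fold higher number (0.00 log units; that floor lies within the scatter) from compound 3 to compound 4; the limit leaves it open whether they differ. The outcome fits a transfer of the change from one core to the other but does not demonstrate one, and the step between the two methoxy compounds, compound 2 and compound 4, cannot be read either: the limit of > 50000 nM in this assay, at which 2 of the 4 values shown sit.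

The compounds shown cover only trifluoromethyl and methoxy on one aryl ring and chloro and iodo on the other, so the true values of the two methoxy compounds remain unknown, and with them any effect of the halogen on the methoxy change. Also open, going by these compounds, is how the series would respond to a different group on these rings, such as an amine or a carboxylic acid in place of trifluoromethyl, and whether such a compound would give a value clear of the limit in this assay.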